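Working notes: from compound 1 to compound 4

A few compounds are considered here, and "the series" means these few. Any claim that something is new, unique, unknown or untested is made for them only; others in the source may bear on it.

Measured so far in a physicochemical assay for acid dissociation:
- compound 1 `CC#CCOc1noc2c1CNCC2`: 7.6
- compound 2 `c1ccc(COc2noc3c2CNCC3)cc1`: 7.5
- compound 3 `COc1noc2c1CN(Cc1ccccc1)CC2`: 6

Compound 1 sits in the upper pair of these three numbers. Compound 2 lies within the scatter of it, while compound 3 lies lower, beyond the scatter.

Compound 4 `C=CCOc1noc2c1CNCC2` has not yet been measured. Compared with compound 1, it carries vinyl in place of prop-1-yn-1-yl on a saturated chain carbon bound to an oxygen on an aromatic ring. Cut one bond further out, the same difference reads but-2-yn-1-yl to allyl.

Within the data shown here, no measured pair isolates this change, so any expectation is indirect. Compound 1 at 7.6 and compound 2 at 7.5 carry different groups at this place, yet their values stay within the scatter of each other. Among the measured compounds shown here, compound 3 differs from both in more than one place and offers no guide to this step. In this assay, no step beyond the scatter is expected, and no firm direction can be assigned. The estimated step is a number 0.10 log units lower from compound 1 to compound 4 (within the scatter). For compound 4 the expected value is 7.5, with an estimated range of 7.2 to 7.8.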

Compound 4, acid dissociation constant: 7.5
Compound 4: the middle estimate sits on the measured number at the digits printed; low and high end bracket the measured number.
By their numbers in this assay, from the lowest: compound 3; then compounds 2, 4 and 1 (each within the scatter of the next).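

Among these compounds, replacing but-2-yn-1-yl with allyl gives, in this assay, a step of a number 0.10 log units lower from compound 1 to compound 4 (within the scatter), and this is the first pair that differs in one place only. Among the compounds shown here, it gives a direct reading for this position on the shared core, where the earlier compounds allowed only an indirect one. In this single pair, prop-1-yn-1-yl, with its triple bond outside aromatic rings, and vinyl, with its double bond outside aromatic rings and one heavy atom fewer, cannot be told apart in this assay. No independent measurement offers an explanation for this result.

As far as these compounds go, whether the same holds at this place for a longer chain such as pentyl, or for a group carrying an amine or a carboxylic acid, remains open. Compound 3, at 6, differs from the other compounds in more than one place, so steps involving it cannot be read, and which of its differences goes with its number stays unresolved.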